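Methoxy Removal on the Shared Core: Working Notes

This account rests on a few compounds, and the source may have more. Where it says the series, first, only, none or still open, it means among the compounds named here.

Compound 1 `COc1ccc2c(/C=C(\C#N)C(=O)c3c[nH]c4cc(OC)ccc34)c[nH]c2c1` gives, in a functional assay on PC-3 cells (Homo sapiens) for cytotoxicity, read by WST assay, with a stated time of 24 h (a higher number here means a weaker inhibitor, a lower number a stronger inhibitor), only a limit, > 50000 nM. Compound 2 `COc1ccc2c(C(=O)/C(C#N)=C/c3c[nH]c4cc(F)ccc34)c[nH]c2c1` gives 36000 nM in this assay. Compound 3 `COc1ccc2c(C(=O)/C(C#N)=C/c3c[nH]c4ccccc34)c[nH]c2c1` gives only a limit in this assay, > 50000 nM. The step of an at least 1.3-fold lower number from compound 1 to compound 2 (0.14 log units; that floor lies within the scatter) and the step of an at least 1.3-fold higher number from compound 2 to compound 3 (0.14 log units; that floor lies within the scatter) both rest on floors that lie within the scatter; the step that the two limits leave unreadable from compound 1 to compound 3 has no readable size, and the limit of > 50000 nM in this assay, at which 2 of the 3 values shown sit, is where two of the three values sit. Compound 1 therefore stands at the weak end of the numbers shown, known only as a limit.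

Compound 4 `COc1ccc2c(/C=C(\C#N)C(=O)c3c[nH]c4ccccc34)c[nH]c2c1` differs from compound 1 by hydrogen in place of methoxy on an aromatic carbon. The step from compound 1 to compound 3 is a change of the same kind, hydrogen in place of methoxy on an aromatic carbon, and both of its ends are limits, so no size can be read from it. Within the data shown here, no measured step therefore points to a shift beyond the scatter. For compound 4 the estimate in this assay is 50000 nM, range 20000 nM to 150000 nM. The expected step of a number no higher from compound 1 to compound 4 (the limit leaves the size open) is accordingly flat, with a high chance that only a limit is returned.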

Compound 4, half-maximal inhibitory concentration: 33300 nM
For compound 4 the middle estimate is 1.5-fold (0.18 log units) above the measured one; low and high end bracket the measured number.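

In this assay, hydrogen in place of methoxy on an aromatic carbon now has a readable floor, an at least 1.5-fold lower number from compound 1 to compound 4 (0.17 log units; that floor lies within the scatter), and removal of this methoxy group leaves a measured number rather than a limit. Compound 3, with the same change at the other methoxy group, gives only a limit, > 50000 nM. The step to that compound cannot be read, the two methoxy positions cannot be ranked, and the limit still marks much of the set: the limit of > 50000 nM in this assay, at which 2 of the 4 values shown sit.

The compounds shown leave open what an amine or a carboxylic acid on this aromatic carbon would give in this assay. On these data alone, the true size of the change from methoxy to hydrogen also stays open, with only a floor available for it.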